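The compounds below may be only part of what the source reports. "The series", "measured", "known", "first", "only" and "open" are said of these compounds alone.

In an ADME assay on HEL cells (Homo sapiens) for cytotoxicity, with a stated time of 3 days (a higher number here means that more compound is tolerated, a lower number that less compound is tolerated), compound 2 `Cc1cc(-n2cccc2)c2ncc(CSCCc3ccccc3)n2c1` gives 100 ug/mL and stands level with compound 3 `Cc1cc(-n2cccc2)c2ncc(CSCc3ccccc3)n2c1`, which gives 100 ug/mL in this assay; the step of no change at the digits printed from compound 2 to compound 3 (within the scatter) lies within the scatter. For compound 1 `Cc1cc(-c2ccoc2)cn2c(CSCCc3ccccc3)cnc12` the record shows (the limit of > 4 ug/mL in this assay, at which 1 of the 3 values shown sits); its value > 4 ug/mL is a limit of this assay and not a number. Compound 4 `Cc1cc(Sc2ccc(Cl)cc2)c2ncc(CSCCc3ccccc3)n2c1` differs from compound 2 by (4-chlorophenyl)sulfanyl in place of 1H-pyrrol-1-yl on an aromatic carbon. Among the compounds with values here, no measured step covers this exchange: the single measured step, no change at the digits printed from compound 2 to compound 3 (within the scatter), concerned another part of the molecule and showed nothing beyond the scatter, so it gives no direction. The expected step is therefore a 2.0-fold lower number from compound 2 to compound 4 (0.30 log units; within the scatter), a modest one or none beyond the scatter. Compound 4 is estimated at 50 ug/mL, with a range from 20 ug/mL to 100 ug/mL.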

Compound 4, minimum cytotoxic concentration: 4 ug/mL
The estimate for compound 4 lay 13-fold (1.10 log units) above the measured number, outside the stated range (below it).
By their numbers in this assay, from the lowest: compound 4; then compounds 2 and 3 (each within the scatter of the next).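

Placing (4-chlorophenyl)sulfanyl in place of 1H-pyrrol-1-yl on the aromatic carbon gives a 25-fold lower number from compound 2 to compound 4 (1.40 log units; beyond the scatter) in this assay. This is the first step beyond the scatter among the compounds shown, so the tolerated concentration responds to the group at this position, whereas the change on the chain gave no change at the digits printed from compound 2 to compound 3 (within the scatter). The data shown offer no measured explanation for this step. The sulfur and the chlorine enter together, and the compounds shown do not separate their contributions. Going by these compounds, how a morpholine or a primary amine on this carbon would fare in this assay remains open.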